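Swapping the anilide substituent under a cytotoxicity ceiling

The source may report more compounds than this note shows. Statements on the series, on what has been measured and on what is new or still open speak of the compounds shown alone.

Compound 2 `COc1cc2nc([S+]([O-])CC(=O)Nc3ccccc3[N+](=O)[O-])nc(Nc3c(Cl)cc(/C=C/C#N)cc3Cl)c2cc1OC` was tested in an ADME assay on MT4 cells (Homo sapiens) for cytotoxicity, read by MTT assay, with a stated time of 5 days; a lower number here means that less compound is tolerated, a higher number that more compound is tolerated. For compound 2 the measurement gave only a limit, > 199000 nM, as noted by the limit of > 199000 nM in this assay, at which 1 of the 2 values shown sits. Compound 1 `COc1cc2nc([S+]([O-])CC(=O)Nc3ccc(F)cc3)nc(Nc3c(C)cc(/C=C/C#N)cc3C)c2cc1OC` gives 27400 nM in this assay. Compound 3 `COc1cc2nc([S+]([O-])CC(=O)Nc3ccc(C#N)cc3)nc(Nc3c(Cl)cc(/C=C/C#N)cc3Cl)c2cc1OC` has not yet been measured; it differs from compound 2 in one place (4-cyanophenyl in place of 2-nitrophenyl on an amide-type nitrogen). For the measured compounds named here, no pair of measured compounds shows this change, so its effect is unknown here. Compound 3 is expected to give about 100000 nM, within 30000 nM to 250000 nM. The estimated step of an at least 1.9-fold lower number from compound 2 to compound 3 (0.29 log units; that floor lies within the scatter) is expected to be modest and downward, possibly no larger than the scatter.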

Compound 3, half-maximal cytotoxic concentration: >= 188000 nM
Compound 3: only a limit was reported; the forecaster's own chance of this, stated with the estimate: 45%; middle value at least 1.8-fold (0.27 log units) away from the limit.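

For the compounds shown here, compound 2 and compound 3 each carry only a limit, and no step between them can be read. The compounds shown leave open where their actual values lie and what 4-cyanophenyl in place of 2-nitrophenyl changes.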